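Cyclopentylamino for fluoro on the pyridine of compound 1

The source may hold more compounds than are shown below. What is called first, only, known or untested is meant among the compounds shown, and "the series" means these compounds.

Compound 1 `Fc1ccc(-c2nn3c(NC4CCCC4)cccc3c2-c2ccnc(F)c2)cc1` carries a fluoro group on the six-membered aromatic ring that sits beside the fluorophenyl group on the shared core. In an ADME assay on Vero cells (Chlorocebus sabaeus) for cytotoxicity (on this read-out higher numbers stand for lower toxicity in this test and lower numbers for higher toxicity in this test), compound 1 has only the entry "not determined" (no result reported), so no number anchors it. The same holds for compound 2 `Fc1ccc(-c2nn3c(NC4CCCC4)cccc3c2-c2cccnc2F)cc1`, for which this assay reads "not determined" (no result reported). Among the measured compounds shown here, the one compound of the series with a number is compound 3 `Nc1nccc(-c2c(-c3ccc(F)cc3)nn3c(NC4CCCC4)cccc23)n1`, which in this assay gives 46000 nM; it carries an amino group on a different six-membered aromatic ring in place of the fluoro, so nothing from it can be reduced to a single-point step toward compound 1.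

Compound 4 `Fc1ccc(-c2nn3c(NC4CCCC4)cccc3c2-c2ccnc(NC3CCCC3)c2)cc1` is the unmeasured target. The change from compound 1 is cyclopentylamino in place of fluoro on an aromatic carbon. For the measured compounds named here, no step between two measured compounds exists in this assay, so the size of this step cannot be read from the data. With compound 1 itself without a number, the expectation for this assay can only rest on compound 3 at 46000 nM, and the step is expected to stay within the scatter or to lower the number modestly.

For compound 4 the value in this assay is estimated at 30000 nM, with a range from 10000 nM to 90000 nM.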

Compound 4, half-maximal cytotoxic concentration: > 40000 nM
Compound 4: a limit, no number (the forecaster's own chance of this, stated with the estimate: 35%); middle value at least 1.3-fold (0.12 log units) away from the limit.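

In this assay compound 4 gives > 40000 nM, which is a limit and not a number. Neither compound 1 nor compound 4 carries a single number in this read-out, so no step can be read between them. The compounds shown leave open what cyclopentylamino in place of fluoro does to the value in this assay.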